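This account rests on a few compounds, and the source may have more. Where it says the series, first, only, none or still open, it means among the compounds named here.

Measured so far in an ADME assay on HEK293 cells (Homo sapiens) for cytotoxicity, read by resazurin assay, with a stated time of 48 h; on this read-out lower numbers stand for higher toxicity in this test and higher numbers for lower toxicity in this test:

- compound 1 `O=S(=O)(Nc1ccc2oc(-c3ccccc3)nc2c1)c1ccc(Cl)c(Cl)c1`: 71000 nM
- compound 2 `O=S(=O)(Nc1ccc2oc(-c3ccccc3)nc2c1)c1ccccc1Cl`: 73000 nM
- compound 3 `COc1cccc(S(=O)(=O)Nc2ccc3oc(-c4ccccc4)nc3c2)c1`: 63000 nM

Compound 3 carries the lowest of the three numbers, but its gaps to compound 1 and to compound 2 are both within the scatter, so the three compounds cannot be ranked against each other.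

The next step is 4-methylphenyl in place of 3-methoxyphenyl on a sulfonyl sulfur, giving compound 4 `Cc1ccc(S(=O)(=O)Nc2ccc3oc(-c4ccccc4)nc3c2)cc1`, not yet measured.

Among the compounds with values here, every measured step so far exchanges the aryl group on the same sulfonyl sulfur: a 1.0-fold higher number from compound 1 to compound 2 (0.01 log units; within the scatter), a 1.1-fold lower number from compound 1 to compound 3 (0.05 log units; within the scatter) and a 1.2-fold lower number from compound 2 to compound 3 (0.06 log units; within the scatter), all within the scatter. On that basis no step beyond the scatter is expected for the change to compound 4, that is a 1.1-fold higher number from compound 3 to compound 4 (0.03 log units; within the scatter) in this assay. Compound 4 is estimated at 67000 nM, with a range of 35000 nM to 130000 nM.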

Compound 4, half-maximal cytotoxic concentration: 75000 nM
The estimate for compound 4 lay 1.1-fold (0.05 log units) below the measured number; measured number inside the range.
By their numbers in this assay, from the lowest: compounds 3, 1, 2 and 4 (each within the scatter of the next).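

In this assay the new group, 4-methylphenyl, carries no hydrogen-bond acceptor, unlike 3-methoxyphenyl, yet the change gives a 1.2-fold higher number from compound 3 to compound 4 (0.08 log units; within the scatter) as its step, while a 1.0-fold higher number from compound 2 to compound 4 (0.01 log units; within the scatter) and a 1.1-fold higher number from compound 1 to compound 4 (0.02 log units; within the scatter) complete the comparison. Four aryl groups on the sulfonyl sulfur, now including one with only carbon among its heavy atoms, thus show no step beyond the scatter. No measured evidence bears on the reason for this.

Still open, going by these compounds, is whether a phenyl carrying an amine or a carboxylic acid on the sulfonyl sulfur would give a step beyond the scatter. Changes to the shared core also remain open.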